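The source may hold more compounds than are shown below. What is called first, only, known or untested is meant among the compounds shown, and "the series" means these compounds.

Measured compounds: compound 1 `COc1cc(C)cc(-c2c(-c3ccnc(-c4ccc(C(C)=O)cc4)c3)cnn2CC#N)c1` gives 17% in a functional assay on A498 cells (Homo sapiens) for cytotoxicity, read by sulforhodamine B assay, with a stated time of 48 h, tested at 1 uM; a higher number here means a weaker effect of the compound at the concentration tested, a lower number a stronger effect; compound 2 `Cc1cc(O)cc(-c2nn(CC#N)cc2-c2ccnc(-c3ccc(Oc4ccccc4)cc3)c2)c1` gives 26%; compound 3 `COc1cc(C)cc(-c2nn(CC#N)cc2-c2ccnc(-c3ccc(N(C)C)cc3)c2)c1` gives -26%.

Compound 3 stands lowest of the three. Its nearest neighbour on the numbers is compound 1, which lies higher by a margin beyond the scatter, and compound 2 lies higher still, also beyond the scatter. Compound 4 `Cc1cc(O)cc(-c2nn(CC#N)cc2-c2ccnc(-c3ccc(N(C)C)cc3)c2)c1` is the next compound; it differs from compound 3 in one place: hydrogen in place of methyl on an oxygen on an aromatic ring. Within the data shown here, no pair of measured compounds differs in this place alone. Compound 1 and compound 2 differ in several places, and their two values lie within the scatter of each other. A small step, a number 16 percentage points higher from compound 3 to compound 4 (beyond the scatter), toward a higher number is expected. Compound 4 is estimated at -10%, within a range of -40% to 25%.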

Compound 4, a percentage reported as activity, at one concentration (the size of the read-out at that concentration, not a potency): 5%
Compound 4: the middle estimate sits 15 percentage points below what was measured; measured number inside the range.
By their numbers in this assay, from the lowest: compound 3; then compound 4; then compounds 1 and 2 (each within the scatter of the next).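

In this assay, hydroxy in place of methoxy on the aromatic ring gives a number 31 percentage points higher from compound 3 to compound 4 (beyond the scatter) and so weakens the effect at the tested concentration, which shows that this position responds to the change. With the hydroxy kept, dimethylamino in place of phenoxy gives a number 21 percentage points lower from compound 2 to compound 4 (beyond the scatter) as a separate, opposite shift at another place on the molecule. No evidence is available that would explain either step. The compounds shown leave open whether the methoxy to hydroxy step keeps its size when phenoxy replaces dimethylamino. They also leave open how an ethoxy group or an amine would read at this position.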